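The source may hold more compounds than are shown below. What is called first, only, known or untested is meant among the compounds shown, and "the series" means these compounds.

In a functional assay on C8166 cells (Homo sapiens) for cytotoxicity, read by MTT assay (a lower number here means that less compound is tolerated, a higher number that more compound is tolerated), compound 1 `Cc1cc(S(N)(=O)=O)ccc1NC(=O)COc1ccc(Cl)cc1NC(=O)c1cccc(C(F)(F)F)c1` gives 124000 nM and compound 2 `Cc1ccc(C(=O)Nc2cc(Cl)ccc2OCC(=O)Nc2ccc(S(N)(=O)=O)cc2C)cc1C` gives 84100 nM which places the two within the scatter of each other. Compound 3 `Cc1cc(S(N)(=O)=O)ccc1NC(=O)COc1ccc(Cl)cc1NC(=O)c1ccc(Cl)cc1Cl` has 2,4-dichlorophenyl in place of 3,4-dimethylphenyl on a carbonyl carbon. For the measured compounds named here, the one measured change at this place is a 1.5-fold lower number from compound 1 to compound 2 (0.17 log units; within the scatter) and it gives no ground to expect a shift beyond the scatter. The expected step is a 1.1-fold higher number from compound 2 to compound 3 (0.05 log units; within the scatter) with no firm direction. In this assay compound 3 is estimated at 95000 nM with 40000 nM to 200000 nM as the expected range.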

Compound 3, half-maximal cytotoxic concentration: 61100 nM
Beside the measured number, compound 3's estimate is 1.6-fold (0.19 log units) above it; measured number inside the range.
By their numbers in this assay, from the lowest: compounds 3, 2 and 1 (each within the scatter of the next, the first and the last beyond it).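

For the compounds shown here, with 2,4-dichlorophenyl on the carbonyl carbon, this assay shows for the first time at this place a step beyond the scatter, though a modest one: a 2.0-fold lower number from compound 1 to compound 3 (0.31 log units; beyond the scatter). The change from 3,4-dimethylphenyl stays within the scatter, at a 1.4-fold lower number from compound 2 to compound 3 (0.14 log units; within the scatter), so compound 2 cannot be separated from either of the other two. Nothing available explains these differences. Going by these compounds, all three groups here are substituted phenyl rings, so it remains open how a carboxylic acid or an amine on that ring, or a cyclohexyl group in its place, would read in this assay.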